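The source may hold more compounds than are shown below. What is called first, only, known or untested is meant among the compounds shown, and "the series" means these compounds.

Measured in a functional assay on BT-549 cells (Homo sapiens) for inhibition, read by sulforhodamine B assay, with a stated time of 48 h; a higher number here means a weaker inhibitor of growth, a lower number a stronger inhibitor of growth:
compound 1 (`COc1ccc(-c2cc(/C=C/C(=O)c3ccc(N)cc3)[nH]n2)cc1`): 4780 nM
compound 2 (`COc1cc(-c2cc(/C=C/C(=O)c3ccc(N)cc3)[nH]n2)cc(OC)c1OC`): 2820 nM
compound 3 (`COc1ccc(C(=O)/C=C/c2cc(-c3cc(OC)c(OC)c(OC)c3)n[nH]2)cc1`): 3860 nM

Compound 2 carries the smallest of the three numbers, but each neighbour sits within the scatter of it: the step of a 1.4-fold higher number from compound 2 to compound 3 (0.14 log units; within the scatter) is a small one, and compound 1, at 4780 nM, differs from compound 2 by no more than that scatter allows.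

Compound 4 (`COc1ccc(-c2cc(/C=C/C(=O)c3ccc(N)cc3)[nH]n2)cc1OC`) is reached from compound 2 by hydrogen in place of methoxy on an aromatic carbon. Within the data shown here, the only measured step, a 1.4-fold higher number from compound 2 to compound 3 (0.14 log units; within the scatter), concerns the other end of the molecule and was within the scatter, so it bears on this change only loosely. Among the measured compounds shown here, no measured step removes a methoxy group from the ring that carries three of them; what can be said is that compound 1, with one methoxy group on that ring, and compound 2, with three, give numbers within the scatter of each other, and compound 4 stands between them in methoxy count. On that basis no change beyond the scatter is expected in this assay.

Compound 4 is therefore estimated at 3500 nM, in the range 1500 nM to 8000 nM, which means an expected step of a 1.2-fold higher number from compound 2 to compound 4 (0.09 log units; within the scatter).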

Compound 4, concentration for total growth inhibition: 2940 nM
For compound 4 the middle estimate is 1.2-fold (0.08 log units) above the measured one, and the stated range covers the measured number.
By their numbers in this assay, from the lowest: compounds 2, 4, 3 and 1 (each within the scatter of the next).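

In this assay, the methoxy group on this ring can now be read directly: hydrogen at the aromatic carbon ortho to a methoxy group and meta to a large group gives a small step (a 1.0-fold higher number from compound 2 to compound 4 (0.02 log units; within the scatter)). The same applies to the step that adds a methoxy group to the ring of compound 1 (a 1.6-fold lower number from compound 1 to compound 4 (0.21 log units; within the scatter)). Compounds 1, 4 and 2, with one, two and three methoxy groups on that ring, therefore form a series in which neither single step leaves the scatter, so these steps show no dependence of the number on methoxy count among these three compounds. Nothing available explains this insensitivity.

The compounds shown do not say whether a hydroxyl group, a chlorine atom or an amine at this position would give a step beyond the scatter, or whether a ring with no methoxy group at all would do so. They also leave open whether the same flat result holds when the amino group on the other ring is replaced, as in compound 3, since that compound has no partner with fewer methoxy groups.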